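Shortening the sulfonyl chain: from compound 2 to compound 4

The compounds below may be only part of what the source reports. "The series", "measured", "known", "first", "only" and "open" are said of these compounds alone.

Three compounds share one core and differ only in the group on the sulfonyl sulfur. Compound 1 `O=S(=O)(/C=C/c1ccc(O)c(O)c1)CC1CCCO1` gives 10500 nM in a functional assay, read by fluorescence and spectrophotometry, with a stated time of 1 h; on this read-out lower numbers stand for an effect already at smaller amounts and higher numbers for an effect only at larger amounts of compound. Among the compounds with values here, compound 3 `O=S(=O)(/C=C/c1ccc(O)c(O)c1)CC1CCCCC1` gives 7500 nM, and the one measured step between neighbours, a 1.4-fold lower number from compound 1 to compound 3 (0.15 log units; within the scatter), stays within the scatter. Compound 2 `CCCCCCCCCCCCS(=O)(=O)/C=C/c1ccc(O)c(O)c1` gives 8500 nM; its number is the second highest of the three, but it lies within the scatter of compound 3 and of compound 1, so no order among the three can be read from these values.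

Compound 4 `C=CCCCCCCS(=O)(=O)/C=C/c1ccc(O)c(O)c1` carries the change (vinyl in place of hexyl on a saturated chain carbon, six bonds along the chain from a sulfonyl sulfur), sitting on a saturated chain carbon, six bonds along the chain from a sulfonyl sulfur. Within the data shown here, no measured step touches this part of the chain; the only step on record concerns the carbon bound to the sulfonyl sulfur, and it stayed within the scatter. Among the measured compounds shown here, as the three groups tried so far, a ring-bearing short chain, a cyclohexyl-bearing chain and a long straight chain, all land within the scatter of one another, the sulfonyl substituent seems to matter little here, though only three compounds support that.

Compound 4 is therefore expected near compound 2, with a step of a 1.1-fold higher number from compound 2 to compound 4 (0.02 log units; within the scatter) inside the scatter, giving an estimated 9000 nM, between 4500 nM and 18000 nM.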

Compound 4, half-maximal effective concentration: 6400 nM
The estimate for compound 4 lay 1.4-fold (0.15 log units) above the measured number; the measured number falls inside the stated range.
By their numbers in this assay, from the lowest: compounds 4, 3, 2 and 1 (each within the scatter of the next).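

In this assay, the place six bonds along the chain from a sulfonyl sulfur now has its first measured step: vinyl in place of hexyl gives a 1.3-fold lower number from compound 2 to compound 4 (0.12 log units; within the scatter), so removing this much of the chain and adding a double bond outside aromatic rings leaves the number within the scatter. Seen as a whole group on the saturated chain carbon bound to a sulfonyl sulfur, hept-6-en-1-yl gives a 1.2-fold lower number from compound 3 to compound 4 (0.07 log units; within the scatter) against cyclohexyl and a 1.6-fold lower number from compound 1 to compound 4 (0.22 log units; within the scatter) against oxolan-2-yl, so all four compounds remain without a readable order, and even the largest of these steps does not leave the scatter. No measurement on hand offers an explanation for these results.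

Still open, going by these compounds, is whether any group on the sulfonyl sulfur can move the number beyond the scatter, for example a methyl group, or a chain ending in an amine or a carboxylic acid. On these data alone, the separate contributions of the double bond and the chain length also remain open, as the step from hexyl to vinyl alters both at once.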